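Swapping Methoxy for Nitro on the Ester Ring

The compounds below may be only part of what the source reports. "The series", "measured", "known", "first", "only" and "open" are said of these compounds alone.

Among the compounds with values here, compound 1 `COc1ccc(C(=O)ON=C2CC(c3ccc(O)c(OC)c3)N(C)C(c3ccc(O)c(OC)c3)C2)cc1` gives 33000 nM in a functional assay, read by spectrophotometry, with a stated time of 30 min (a higher number here means a weaker inhibitor, a lower number a stronger inhibitor), the lower of the two numbers measured so far. Within the data shown here, compound 2 `COc1cc(C2CC(=NOC(=O)c3ccc(Cl)cc3)CC(c3ccc(O)c(OC)c3)N2C)ccc1O` gives 112000 nM, and the only known step, a 3.4-fold higher number from compound 1 to compound 2 (0.53 log units; beyond the scatter), is a modest weakening. Compound 3 `COc1cc(C2CC(=NOC(=O)c3ccc([N+](=O)[O-])cc3)CC(c3ccc(O)c(OC)c3)N2C)ccc1O` differs from compound 1 by nitro in place of methoxy on an aromatic carbon. Among the measured compounds shown here, no measured step tests exactly this change, yet a modest weakening is expected for compound 3 because a 3.4-fold higher number from compound 1 to compound 2 (0.53 log units; beyond the scatter) already went that way for a different swap at the same place. The estimated step is a 1.8-fold higher number from compound 1 to compound 3 (0.26 log units; within the scatter). Compound 3 is therefore expected to give 60000 nM, plausibly between 20000 nM and 180000 nM.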

Compound 3, half-maximal inhibitory concentration: 79000 nM
For compound 3 the middle estimate is 1.3-fold (0.12 log units) below the measured one; the measured number falls inside the stated range.
By their numbers in this assay, from the lowest: compound 1; then compounds 3 and 2 (each within the scatter of the next).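

In this assay nitro gives a 2.4-fold higher number from compound 1 to compound 3 (0.38 log units; beyond the scatter) and so joins chloro as a second group at this place on the ester ring that weakens the result relative to methoxy. Within the data shown here, the two replacements cannot be separated, with a 1.4-fold lower number from compound 2 to compound 3 (0.15 log units; within the scatter) as the only step between them. Nothing measured here explains why either replacement falls short of methoxy.

On these data alone, whether any group at this place can match or beat methoxy stays open. An amine, a carboxylic acid or a longer chain such as butoxy could answer that.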